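Removing the Hexyl Chain From a Non-Toxic Bicyclic Core

The source may report more compounds than this note shows. Statements on the series, on what has been measured and on what is new or still open speak of the compounds shown alone.

Compound 3 `CCCCCCc1cc2cn(COCCO)c(O)nc-2n1` stands at a limit in a functional assay on HEL cells (Homo sapiens); on this read-out lower numbers stand for higher toxicity in this test and higher numbers for lower toxicity in this test: compound 3 gives > 200000 nM, which is a limit of the assay and not a number. The two related compounds also end at limits. Compound 1 `CCCCCCC#Cc1cc2cn(COCCO)c(=O)nc2o1` gives > 50000 nM in this assay, a limit. Compound 2 `CCCCCCCCCc1cc2cn(COCCO)c(=O)nc2o1` gives >= 100000 nM in this assay, likewise a limit. Going by the values given here, none of the three therefore shows a measurable toxicity on these cells, and no step between them can be sized.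

Compound 4 `OCCOCn1cc2ccnc-2nc1O` differs from compound 3 by hydrogen in place of hexyl on an aromatic carbon. Among the compounds with values here, with no measured step to lean on, the expected step of a number no higher from compound 3 to compound 4 (the limit leaves the size open) is none beyond the scatter. Compound 4 is thus expected to give 200000 nM, somewhere between 100000 nM and 400000 nM, most likely again reported only as a limit.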

Compound 4, half-maximal cytotoxic concentration: > 200000 nM
Compound 4: a limit, no number; the forecaster's own chance of this, stated with the estimate: 85%; the middle value sits exactly at the limit.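

Going by these compounds alone, compound 3 and compound 4 both end at a limit and not at a number, so no step between them can be read. The compounds shown leave open whether hydrogen in place of hexyl changes anything in this assay.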